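Swapping cyclohexyl for 3,4-dimethylphenyl on two related cores

The source may hold more compounds than are shown below. What is called first, only, known or untested is meant among the compounds shown, and "the series" means these compounds.

Compound 1 `Nc1ncnc2c1ccn2CCNC(=O)Cn1cnc(C(=O)NC2CCCCC2)n1` carries a cyclohexyl group on an amide-type nitrogen. In an assay for inhibition of histone-lysine N-methyltransferase, H3 lysine-79 specific (Homo sapiens), read by luminescence, with a stated time of 1 h (a lower number here means a stronger inhibitor, a higher number a weaker inhibitor), compound 1 reaches only the limit of the assay, > 100000 nM. Compound 2 `Cc1ccc(NC(=O)c2ncn(CC(=O)NCCn3ccc4c(N)ncnc43)n2)cc1C` differs by 3,4-dimethylphenyl in place of cyclohexyl on an amide-type nitrogen, and in this assay compound 2 gives 10900 nM. That is an at least 9.1-fold lower number from compound 1 to compound 2 (0.96 log units; beyond the scatter), a step that rests on (the limit of > 100000 nM in this assay, at which 2 of the 3 values shown sit).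

Compound 3 `O=C(Cn1cnc(C(=O)NC2CCCCC2)n1)NCc1ccc2[nH]ncc2c1` has a different core from compound 1; the difference between the two cores is not broken down here. In this assay compound 3 also reports only a limit, > 100000 nM.

Compound 4 `Cc1ccc(NC(=O)c2ncn(CC(=O)NCc3ccc4[nH]ncc4c3)n2)cc1C` is compound 3 with 3,4-dimethylphenyl in place of cyclohexyl on an amide-type nitrogen, the same change that turned compound 1 into compound 2. Because compound 1 and compound 3 both sit at the limit of > 100000 nM in this assay, at which 2 of the 3 values shown sit, and because the change from compound 1 to compound 2 gave an at least 9.1-fold lower number from compound 1 to compound 2 (0.96 log units; beyond the scatter), a comparable drop is expected here. The step from compound 3 to compound 4 is therefore estimated at an at least 6.6-fold lower number from compound 3 to compound 4 (0.82 log units; beyond the scatter), with the caution that compound 3 is itself only a limit. Compound 4 is expected to give about 15000 nM, most likely between 3000 nM and 100000 nM.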

Compound 4, half-maximal inhibitory concentration: 36900 nM
The estimate for compound 4 lay 2.5-fold (0.39 log units) below the measured number; the measured number falls inside the stated range.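

In this assay, 3,4-dimethylphenyl in place of cyclohexyl on the amide-type nitrogen also lowers the number on the second core, giving an at least 2.7-fold lower number from compound 3 to compound 4 (0.43 log units; beyond the scatter). The direction of the change therefore carries over from the core of compound 1 to the core of compound 3, but the two steps cannot be ranked by size: the same change on two cores in this assay, an at least 9.1-fold lower number (0.96 log units; beyond the scatter) from compound 1 to compound 2 and an at least 2.7-fold lower number (0.43 log units; beyond the scatter) from compound 3 to compound 4; the limit leaves it open whether they differ. On these data alone, both steps start from a limit, so each gives only a minimum size, and the full effect of the change on either core remains unknown: the limit of > 100000 nM in this assay, at which 2 of the 4 values shown sit.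

With only these two groups shown on that nitrogen, it remains open whether the lower number comes from the aromatic ring itself or from its two methyl groups, a question that plain phenyl could help to settle. Also open, as far as these compounds go, is whether the change carries over to further cores, and how an amine or a carboxylic acid on the aromatic ring would alter the number.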